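The compounds below may be only part of what the source reports. "The series", "measured", "known", "first", "only" and "open" are said of these compounds alone.

Measured compounds:
Compound 1 `COc1ccc(-c2cc(/C=C/C(=O)c3ccc(N)cc3)[nH]n2)cc1`: 100%
Compound 2 `COc1cc(-c2cc(/C=C/C(=O)c3ccc(N)cc3)[nH]n2)cc(OC)c1OC`: 94%

In a functional assay on HCT-15 cells (Homo sapiens) for cytotoxicity, read by sulforhodamine B assay, with a stated time of 48 h, tested at 0.1 uM (on this read-out higher numbers stand for a weaker effect at the one concentration tested and lower numbers for a stronger effect), compound 1 gives 100% and compound 2 gives 94%. Compound 2 holds the lower of the two numbers, but its gap to compound 1 lies within the scatter, so the two compounds read alike at this concentration and neither shows much effect. Going by the values given here, no step between measured compounds that differ in one place exists here, so the series itself offers no guide to any single change.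

Compound 3 `COc1ccc(C(=O)/C=C/c2cc(-c3cc(OC)c(OC)c(OC)c3)n[nH]2)cc1OC` is not yet measured. It differs from compound 2 in one place: 3,4-dimethoxyphenyl in place of 4-aminophenyl on a carbonyl carbon. Among the compounds with values here, with no comparable step on record, no step beyond the scatter is expected in this assay in either direction. Compound 3 is therefore estimated at 95%, with a range from 80% to 105%. The estimated step is a number 1 percentage points higher from compound 2 to compound 3 (within the scatter).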

Compound 3, a percentage reported as activity, at one concentration (the size of the read-out at that concentration, not a potency): 98%
For compound 3 the middle estimate is 3 percentage points below the measured one; measured number inside the range.
By their numbers in this assay, from the lowest: compounds 2, 3 and 1 (each within the scatter of the next).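

At the carbonyl carbon, 3,4-dimethoxyphenyl in place of 4-aminophenyl gives, in this assay, a number 4 percentage points higher from compound 2 to compound 3 (within the scatter). This is the first single change shown at this position, and it leaves compound 3 reading alike with compound 2 at the one concentration tested, so the 4-aminophenyl group is not required for the reading seen here. With little effect in either compound, the step cannot show whether either group adds to or takes away from cytotoxicity, and nothing on hand explains the result.

From the compounds shown here alone, whether a carboxylic acid or a morpholine on this carbonyl carbon would separate from compound 2 remains open. Also open, going by these compounds, is whether compound 2 and compound 3 stay alike at higher concentrations, where an effect could be read.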